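The source may hold more compounds than are shown below. What is called first, only, known or untested is meant among the compounds shown, and "the series" means these compounds.

Compound 1 `COC(=O)c1ccc(CN(CCCc2c(N)nc(N)nc2O)c2cc(F)c([N+](=O)[O-])cc2[N+](=O)[O-])cc1` is a weak cytotoxic agent: in a functional assay on CCRF-CEM cells (Homo sapiens) for cytotoxicity, in the absence of a further agent (a lower number here means a stronger inhibitor, a higher number a weaker inhibitor), compound 1 gives 2500 nM. Compound 3 `Nc1nc(N)c(CCCNc2cc(F)c([N+](=O)[O-])cc2[N+](=O)[O-])c(O)n1` keeps the same core and gives 1000 nM in this assay. The only difference between them is hydrogen in place of 4-(methoxycarbonyl)benzyl on a nitrogen on an aromatic ring and this produced a 2.5-fold lower number from compound 1 to compound 3 (0.40 log units; beyond the scatter).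

Compound 2 `COC(=O)c1ccc(CN(CCCc2c(N)nc(N)nc2O)c2ccc([N+](=O)[O-])c(F)c2F)cc1` is built on a different core; how the two cores differ is not broken down here. In this assay compound 2 gives 41000 nM, the highest of the three numbers.

Compound 4 `Nc1nc(N)c(CCCNc2ccc([N+](=O)[O-])c(F)c2F)c(O)n1` is the not yet measured partner of compound 2, differing from it by hydrogen in place of 4-(methoxycarbonyl)benzyl on a nitrogen on an aromatic ring, the same change seen between compound 1 and compound 3, at the same kind of position. A step of similar size is expected, which rests on a 2.5-fold lower number from compound 1 to compound 3 (0.40 log units; beyond the scatter). Compound 4 is therefore expected to show a 2.6-fold lower number from compound 2 to compound 4 (0.41 log units; beyond the scatter). Compound 4 is estimated at 16000 nM, most likely between 6000 nM and 40000 nM.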

Compound 4, half-maximal inhibitory concentration: 76000 nM
Beside the measured number, compound 4's estimate is 4.8-fold (0.68 log units) below it; measured number above the stated range.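

The same change does not behave alike on the two cores in this assay, and the two steps differ by more than repeat measurements would explain: the same change on two cores in this assay, a 2.5-fold lower number (0.40 log units; beyond the scatter) from compound 1 to compound 3 and a 1.9-fold higher number (0.27 log units; within the scatter) from compound 2 to compound 4, 4.6-fold (0.67 log units) apart, beyond the scatter of two such steps. On the second core, the change gives a 1.9-fold higher number from compound 2 to compound 4 (0.27 log units; within the scatter), so there the hydrogen and the 4-(methoxycarbonyl)benzyl group cannot be told apart. The size of a step seen on one core therefore does not carry over to the other, but two pairs cannot show why, or predict the step on a further core.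

The compounds shown leave open how a plain benzyl or a methyl group on that nitrogen would behave on each core. They also leave open whether a carboxylic acid in place of the methyl ester would alter either step.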